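This account rests on a few compounds, and the source may have more. Where it says the series, first, only, none or still open, it means among the compounds named here.

Of the compounds shown here, three have been measured in a functional assay on U-87MG ATCC cells for antiproliferative activity against U-87 MG (Homo sapiens), read by MTT assay, with a stated time of 48 h, tested at 100 uM; on this read-out higher numbers stand for a weaker effect at the one concentration tested and lower numbers for a stronger effect. Compound 1, `COc1ccc(-c2nc(SCC(=O)c3sc(-c4ccccc4)nc3C)nc(N)c2C#N)cc1`, gives 17.2%. Compound 2, `COc1ccc(-c2nc(C)c(C(=O)CSc3nc(-c4ccc(OC)cc4)c(C#N)c(=O)[nH]3)s2)cc1`, gives 11.5%, and compound 3, `Cc1nc(-c2ccc(Cl)cc2)sc1C(=O)CSc1nc(-c2cccc(Cl)c2)c(C#N)c(=O)[nH]1`, gives 12.5%. Compound 1 has the highest of these three numbers, but the gaps to compound 3 and to compound 2 both lie within the usual scatter of this kind of measurement, so no order among the three can be read from them; all three sit in the same weak range at the single concentration tested.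

The next compound, compound 4, `Cc1nc(-c2ccccc2)sc1C(=O)CSc1nc(N)c(C#N)c(-c2ccc(Cl)cc2)n1`, differs from compound 1 in one place: chloro in place of methoxy on an aromatic carbon. For the measured compounds named here, no measured pair shows what this change does in this assay, so there is nothing to anchor a step. Given that the three measured compounds cluster together, the expected step of a number 1.2 percentage points lower from compound 1 to compound 4 (within the scatter) is none beyond the scatter. Compound 4 is therefore estimated to give 16% in this assay, with a plausible range from 8% to 26%.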

Compound 4, a percentage reported as activity, at one concentration (the size of the read-out at that concentration, not a potency): 17.1%
Compound 4: the middle estimate sits 1.1 percentage points below what was measured; the range from low to high includes it.
By their numbers in this assay, from the lowest: compounds 2, 3, 4 and 1 (each within the scatter of the next).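

For the compounds shown here, the pair gives the first one-place comparison in this assay: exchanging 4-methoxyphenyl for 4-chlorophenyl gives a number 0.1 percentage points lower from compound 1 to compound 4 (within the scatter). At this position, on an aromatic carbon para to a large group, methoxy and chloro therefore cannot be told apart in this read-out, even though the change removes a hydrogen-bond acceptor and one heavy atom. No supporting measurement bears on why the two groups read alike.

From the compounds shown here alone, it remains open whether an amine or a carboxylic acid on the same aromatic carbon would also read like methoxy and chloro, or would give a step beyond the scatter. Going by these compounds, since the read-out comes from one concentration and is not a potency, it also remains open whether compound 1 and compound 4 match in potency.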